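A few compounds are considered here, and "the series" means these few. Any claim that something is new, unique, unknown or untested is made for them only; others in the source may bear on it.

Measured compounds in an ADME assay on NCM460 cells (Homo sapiens) for cytotoxicity, read by CCK-8 assay, with a stated time of 48 h; on this read-out lower numbers stand for stronger inhibition and higher numbers for weaker inhibition:

Compound 1 `COc1ccc(/C=C\c2cc(OC)c(OC)c(OC)c2)cc1OCc1ccc(CN[C@H](C(=O)O)[C@H](C)O)cc1`: compound 1 gives > 50000 nM, which is a limit of this assay and not a number.

Compound 2 `COc1ccc(/C=C\c2cc(OC)c(OC)c(OC)c2)cc1OCc1ccc(CN2CCCCC2C(=O)O)cc1`: compound 2 gives > 50000 nM, again a limit of this assay.

Compound 3 `COc1ccc(/C=C\c2cc(OC)c(OC)c(OC)c2)cc1OCc1ccc(CN2CCCCC2C(=O)NCCN)cc1`: compound 3 gives > 50000 nM, also a limit of this assay.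

For the measured compounds named here, compound 3 therefore stands where every value so far stands, as the limit of > 50000 nM in this assay, at which 3 of the 3 values shown sit, shows. Going by the values given here, none of the measured steps can be read: the step from compound 1 to compound 2 is a step that the two limits leave unreadable from compound 1 to compound 2, the step from compound 1 to compound 3 is a step that the two limits leave unreadable from compound 1 to compound 3, and the step from compound 2 to compound 3 is a step that the two limits leave unreadable from compound 2 to compound 3. The unmeasured compound 4 `COc1ccc(/C=C\c2cc(OC)c(OC)c(OC)c2)cc1OCc1ccc(CN2CCCCC2C(=O)NCCNC(=O)OC(C)(C)C)cc1` differs from compound 3 by tert-butoxycarbonyl in place of hydrogen on an amine nitrogen. Among the compounds with values here, no measured step bears on this change, and the three unreadable steps give no direction; with all values at the limit, the expected step in this assay for compound 4 is a step that the limit leaves unreadable from compound 3 to compound 4, most likely again a limit. Compound 4 is estimated at 80000 nM, within 25000 nM to 300000 nM.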

Compound 4, half-maximal inhibitory concentration: 28000 nM
The estimate for compound 4 lay 2.9-fold (0.46 log units) above the measured number; the range from low to high includes it.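

In this assay, compound 4 is the only compound shown that gives a number rather than a limit, which makes tert-butoxycarbonyl on this amine nitrogen the one change here that can be read at all: the limit of > 50000 nM in this assay, at which 3 of the 4 values shown sit. The change gives an at least 1.7-fold lower number from compound 3 to compound 4 (0.25 log units; that floor lies within the scatter), and the same comparison made at the carbonyl carbon gives an at least 1.7-fold lower number from compound 2 to compound 4 (0.25 log units; that floor lies within the scatter). Both steps are floors, so the result shows that this end of the chain tolerates the added group without the value staying at the limit, but it does not fix the size of the step.

As far as these compounds go, the true size stays open, as compound 2 and compound 3 carry only limits. From the compounds shown here alone, it is also open whether a smaller acetyl group or a benzyloxycarbonyl group on the same amine nitrogen would give a number in this assay.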